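Estimating compound 3 when compound 2 has no number

The compounds below may be only part of what the source reports. "The series", "measured", "known", "first", "only" and "open" are said of these compounds alone.

Two related compounds share one core, but only one of them has a usable reading. In a physicochemical assay for lipophilicity, at pH 7.4 (a higher number here means a more lipophilic compound, a lower number a more polar compound), compound 1 (`COCc1ccccc1C1Cc2nccn2C1`) gives 1.8. Compound 2 (`NC(=O)c1ccccc1C1Cc2nccn2C1`) has no single number to stand on, and its entry reads "not determined" (no result reported).

The next structure is compound 3 (`FC(F)Oc1ccccc1C1Cc2nccn2C1`), still unmeasured. The change difluoromethoxy in place of carbamoyl on an aromatic carbon puts difluoromethoxy in place of carbamoyl on an aromatic carbon.

Within the data shown here, no measured step exists to guide this swap, so its size has to be judged. Going by these compounds, a clear upward move in this assay, beyond the usual scatter of repeat measurements, is expected on going to compound 3, although the starting point remains unknown. Among the measured compounds shown here, the only number to anchor on is that of compound 1 at 1.8. The expected value for compound 3 is 2.4, with an estimated range from 1.9 to 2.9.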

Compound 3, distribution coefficient: 2.3
The estimate for compound 3 lay 0.10 log units above the measured number; the range from low to high includes it.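

Among these compounds, with compound 3 there is now a first measured step at this aromatic carbon: in this assay, difluoromethoxy in place of methoxymethyl gives a number 0.50 log units higher from compound 1 to compound 3 (beyond the scatter). The shared core therefore does not fix the reading alone. Among the compounds shown here, exchanging this one group moves the number beyond the usual scatter of repeat measurements, though this is only a single pair of compounds. Nothing available explains why the number rises in this step, so the observation stands without a cause.

Steps involving compound 2 cannot be read, which leaves the carbamoyl group without a place on this scale beside difluoromethoxy and methoxymethyl. Going by these compounds, how an amine, a carboxylic acid or a longer ether chain on this same aromatic carbon would read in this assay also remains open.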